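Replacing 2-nitrophenyl with pyrimidin-2-yl in compound 2

A few compounds are considered here, and "the series" means these few. Any claim that something is new, unique, unknown or untested is made for them only; others in the source may bear on it.

Measured in a functional assay on A549 cells (Homo sapiens) for antiproliferative activity, read by MTT assay, with a stated time of 72 h; on this read-out lower numbers stand for stronger inhibition and higher numbers for weaker inhibition:
- compound 1 `Cc1ccccc1N1CCN(C(=S)SCc2ccc3nc(N)nc(N)c3c2)CC1`: 3920 nM
- compound 2 `Nc1nc(N)c2cc(CSC(=S)N3CCN(c4ccccc4[N+](=O)[O-])CC3)ccc2n1`: 4360 nM

Compound 2 stands level with compound 1, within the scatter. Compound 3 `Nc1nc(N)c2cc(CSC(=S)N3CCN(c4ncccn4)CC3)ccc2n1` replaces 2-nitrophenyl with pyrimidin-2-yl on the amine nitrogen in the ring: pyrimidin-2-yl in place of 2-nitrophenyl on an amine nitrogen in a ring. Among the measured compounds shown here, only one measured step bears on this: a 1.1-fold higher number from compound 1 to compound 2 (0.05 log units; within the scatter), with nitro in place of methyl on an aromatic carbon. That step changed a substituent and left the ring in place, so it gives only weak guidance and no direction. No shift beyond the scatter is expected, though the range stays wide. The expected change is a 1.0-fold higher number from compound 2 to compound 3 (0.01 log units; within the scatter). Compound 3 is estimated at 4500 nM, with an expected range of 1800 nM to 11000 nM.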

Compound 3, half-maximal inhibitory concentration: 4010 nM
Compound 3: middle estimate off by 1.1-fold (0.05 log units), on the high side; measured number inside the range.
By their numbers in this assay, from the lowest: compounds 1, 3 and 2 (each within the scatter of the next).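

In this assay, among the compounds shown here, the earlier compounds changed only a substituent on the aromatic ring, whereas here the ring itself changes, from carbon only to one with 2 hetero atoms. Neither swap moves the number beyond the scatter: pyrimidin-2-yl in place of 2-nitrophenyl gives a 1.1-fold lower number from compound 2 to compound 3 (0.04 log units; within the scatter), and pyrimidin-2-yl in place of 2-methylphenyl gives a 1.0-fold higher number from compound 1 to compound 3 (0.01 log units; within the scatter). No measured evidence is available to explain this level result. All three groups on this amine nitrogen are six-membered aromatic rings. On these data alone, whether a simple methyl, an acetyl or a longer chain ending in an amine would keep the number level remains open.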